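Swapping the amide aryl group on a cytotoxicity-silent scaffold

This account rests on a few compounds, and the source may have more. Where it says the series, first, only, none or still open, it means among the compounds named here.

Compound 1 `C=CC1=C(C(=O)Nc2ccccc2OC)C(c2ccc(F)cc2)OC1` sets the starting point. In a functional assay on A549 cells (Homo sapiens) for cytotoxicity, read by MTT assay, with a stated time of 24 h (on this read-out higher numbers stand for weaker inhibition and lower numbers for stronger inhibition), compound 1 gives only a limit of the assay, > 100000 nM, so its position is a boundary rather than a number. Compound 2 `C=CC1=C(C(=O)Nc2ccccc2OC)C(c2ccc(Cl)c(Cl)c2)OC1` likewise returns a limit in this assay, > 100000 nM. The step that the two limits leave unreadable from compound 1 to compound 2 therefore cannot be read, as both values sit at the limit of > 100000 nM in this assay, at which 2 of the 2 values shown sit.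

Compound 3 `C=CC1=C(C(=O)Nc2cccc(C)c2)C(c2ccc(F)cc2)OC1` carries 3-methylphenyl in place of 2-methoxyphenyl on an amide-type nitrogen. Going by the values given here, no measured step touches this part of the molecule, and the one measured step has no readable size. Nothing in the data points to a shift in this assay beyond the scatter in either direction, so the expected step that the limit leaves unreadable from compound 1 to compound 3 is set at no change. Compound 3 is therefore expected at 150000 nM, within a range from 40000 nM to 500000 nM, with a strong chance that only a limit is reported once more.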

Compound 3, half-maximal inhibitory concentration: > 100000 nM
Compound 3: a limit, no number; the forecaster's own chance of this, stated with the estimate: 80%; the middle value is on the limit's open side.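

In this assay compound 3 also gives only a limit of the assay, > 100000 nM. No step from compound 1 to compound 3 can therefore be read, and all three compounds sit at the same boundary: the limit of > 100000 nM in this assay, at which 3 of the 3 values shown sit.

The compounds shown leave open whether any change to the shared core would give a measurable value in this assay.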